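Two Measured Compounds and a Forecast for a Third

The source may report more compounds than this note shows. Statements on the series, on what has been measured and on what is new or still open speak of the compounds shown alone.

In an assay on CHO cells for displacement of a labelled ligand from C-C chemokine receptor type 4 (Homo sapiens), read by scintillation counting (on this read-out higher numbers stand for weaker inhibition and lower numbers for stronger inhibition), compound 1 `O=C(C1CCCN1)N1CCC2(CCN(c3nccc(NCc4ccc(F)cc4F)n3)CC2)C1` gives 25.1 nM, while compound 2 `Fc1ccc(CNc2ccnc(N3CCC4(CCN(CC5CCCN5)C4)CC3)n2)c(F)c1` gives 3.16 nM. Among the compounds with values here, the only measured step is a 7.9-fold lower number from compound 1 to compound 2 (0.90 log units; beyond the scatter), so compound 2 stands with the lower of the two numbers. Compound 3 `CN(Cc1ccc(Cl)cc1Cl)c1ccnc(N2CCC3(CCN(CC4CCCN4)C3)CC2)n1` differs from compound 2 by (2,4-dichlorobenzyl)(methyl)amino in place of (2,4-difluorobenzyl)amino on an aromatic carbon. Within the data shown here, no measured step bears on this change, since the single step concerns a different group; the author therefore expects a 1.3-fold higher number from compound 2 to compound 3 (0.10 log units; within the scatter), no change beyond the scatter. Compound 3 is estimated at 4 nM in this assay, with a range from 1 nM to 16 nM.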

Compound 3, inhibition constant in the C-C chemokine receptor type 4 assay: 1 nM
Compound 3: middle estimate off by 4.0-fold (0.60 log units), on the high side; measured number inside the range.
By their numbers in the C-C chemokine receptor type 4 assay, from the lowest: compound 3; then compound 2; then compound 1.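

In the C-C chemokine receptor type 4 assay the exchange of (2,4-difluorobenzyl)amino for (2,4-dichlorobenzyl)(methyl)amino gives a 3.2-fold lower number from compound 2 to compound 3 (0.50 log units; beyond the scatter), so a change on this aromatic carbon also moves the number. In a physicochemical assay for solubility, read by chemiluminescence, measured as kinetic solubility (on this read-out higher numbers stand for higher solubility and lower numbers for lower solubility), compound 2 gives 160 ug/mL and compound 3 gives 141 ug/mL. In the physicochemical assay the same exchange gives a 1.1-fold lower number from compound 2 to compound 3 (0.05 log units; within the scatter) and does not separate the two compounds. No evidence at hand accounts for the shift in binding.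

The exchange alters the halogens and the amine nitrogen together, so the step cannot be assigned to either alone. The (2,4-dichlorobenzyl)amino and (2,4-difluorobenzyl)(methyl)amino groups would pull the two apart.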